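Lengthening the side chain of compound 3

The compounds below may be only part of what the source reports. "The series", "measured", "known", "first", "only" and "open" are said of these compounds alone.

In a functional assay on HL-60 cells (Homo sapiens) for antiproliferative activity, read by MTT assay, with a stated time of 48 h (on this read-out higher numbers stand for weaker inhibition and lower numbers for stronger inhibition), compound 3 `CN(C)CCn1c(N)c(-c2nc3cc(Cl)ccc3[nH]2)c2nc(C#N)c(C#N)nc21` reports only a limit, > 50000 nM, so the series offers no number for it. Compound 4 `CN(C)CCCCn1c(N)c(-c2nc3cc(Cl)ccc3[nH]2)c2nc(C#N)c(C#N)nc21` differs from it in one place: 2-(dimethylamino)ethyl in place of dimethylamino on a saturated chain carbon, two bonds along the chain from an aromatic nitrogen. This is 2-(dimethylamino)ethyl in place of dimethylamino on a saturated chain carbon, two bonds along the chain from an aromatic nitrogen, which gives a 4-(dimethylamino)butyl chain. Within the data shown here, no measured step covers this change directly. The nearest evidence comes from compound 1 `CN(C)CCCCn1c(N)c(C#N)c2nc(C#N)c(C#N)nc21` at 12900 nM and compound 2 `CN(C)CCCCn1c(N)c(-c2nc3ccccc3o2)c2nc(C#N)c(C#N)nc21` at 640 nM, which both carry that longer chain. The step of a 20-fold lower number from compound 1 to compound 2 (1.30 log units; beyond the scatter) is large and beyond the scatter, but it lies at an aromatic carbon, not on the chain. Compound 4 combines the chain of compound 2 with the aromatic substituent of compound 3. With compound 2 at 640 nM as the guide, a large move toward stronger inhibition in this assay is expected, of estimated size an at least 41-fold lower number from compound 3 to compound 4 (1.61 log units; beyond the scatter). For compound 4, the estimated value is 1200 nM, with an expected range of 250 nM to 8000 nM.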

Compound 4, half-maximal inhibitory concentration: 1480 nM
Compound 4: the middle estimate sits 1.2-fold (0.09 log units) below what was measured, within the range that was stated.
By their numbers in this assay, from the lowest: compound 2; then compound 4; then compound 1. At a limit, above all of these: compound 3.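

In this assay, among these compounds, with the 5-chloro-1H-benzimidazol-2-yl group held constant, the change from a 2-(dimethylamino)ethyl to a 4-(dimethylamino)butyl chain gives an at least 33-fold lower number from compound 3 to compound 4 (1.52 log units; beyond the scatter), the first step read on the chain itself rather than on an aromatic carbon. Compound 3 stands at a limit and not at a number: the limit of > 50000 nM in this assay, at which 1 of the 4 values shown sits. With the 4-(dimethylamino)butyl chain held constant, 5-chloro-1H-benzimidazol-2-yl gives an 8.7-fold lower number from compound 1 to compound 4 (0.94 log units; beyond the scatter), while the change from 1,3-benzoxazol-2-yl to the same group gives a 2.3-fold higher number from compound 2 to compound 4 (0.36 log units; beyond the scatter), so the aromatic-carbon substituent still moves the read-out on the longer chain.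

From the compounds shown here alone, the read-out for a 3-(dimethylamino)propyl chain, or for a six-carbon chain ending in dimethylamino, remains open. So does the part played by the chloro group, which an unsubstituted 1H-benzimidazol-2-yl group would separate.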